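The source may report more compounds than this note shows. Statements on the series, on what has been measured and on what is new or still open speak of the compounds shown alone.

In a functional assay on a cell-free system (plasma, Rattus norvegicus) (on this read-out higher numbers stand for weaker inhibition and lower numbers for stronger inhibition), compound 1 (`O=C(NCc1cc(Cl)ccc1-n1cnnn1)[C@@H]1CC=NN1C(=O)[C@H](O)c1ccccc1`) gives 1100 nM and compound 2 (`CC(C)(C)[C@@H](O)C(=O)N1C[C@@H]2C[C@@H]2[C@H]1C(=O)NCc1cc(Cl)ccc1-n1cnnn1`) gives 620 nM. Among the measured compounds shown here, these two values lie within the usual scatter of each other, so compound 1 sits level with the only other measured compound. Compound 3 (`CCCC[C@@H](O)C(=O)N1N=CC[C@H]1C(=O)NCc1cc(Cl)ccc1-n1cnnn1`) keeps the core of compound 1 and carries butyl in place of phenyl on a saturated chain carbon bound to a carbonyl carbon and an oxygen on a saturated carbon. For the measured compounds named here, no pair of measured compounds tests this exchange, so the data offer no direct guide to its size. A small move toward a somewhat higher number is expected in this assay, quite possibly none beyond the scatter. The estimated change is a 1.3-fold higher number from compound 1 to compound 3 (0.10 log units; within the scatter). For compound 3 the expected value is 1400 nM, with an estimated range of 480 nM to 4000 nM.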

Compound 3, half-maximal inhibitory concentration in the Rattus norvegicus assay: 540 nM
Beside the measured number, compound 3's estimate is 2.6-fold (0.41 log units) above it; low and high end bracket the measured number.
By their numbers in the Rattus norvegicus assay, from the lowest: compounds 3, 2 and 1 (each within the scatter of the next, the first and the last beyond it).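

In the Rattus norvegicus assay compound 1 gives 1100 nM and compound 3 gives 540 nM, and the exchange of phenyl for butyl on a saturated chain carbon bound to a carbonyl carbon and an oxygen on a saturated carbon gives a 2.0-fold lower number from compound 1 to compound 3 (0.31 log units; beyond the scatter). This modest gain in inhibition shows that, on this core, an aromatic ring is not required at this place to keep inhibition, and that an open chain can go somewhat further. In a physicochemical assay for solubility, measured as kinetic solubility, at pH 6.8 (a higher number here means a more soluble compound, a lower number a less soluble compound), compound 1 gives 98000 nM and compound 3 gives 59000 nM; the same exchange gives a 1.7-fold lower number from compound 1 to compound 3 (0.22 log units; within the scatter) and stays within the scatter, so that read-out does not separate the two compounds, and nothing measured here explains the step in inhibition.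

From the compounds shown here alone, whether a propyl group, a longer chain, or a chain ending in an amine or a carboxylic acid would do better at this place remains open. So does whether the step would carry over to the core of compound 2.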